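The source may hold more compounds than are shown below. What is called first, only, known or untested is meant among the compounds shown, and "the series" means these compounds.

Compound 1 `CONC(=O)[C@@H]1CC=C(CCC=C(C)C)C[C@H]1c1ccccc1` gives 2700 nM in an assay on isolated protein for inhibition of Apoptosis regulator Bcl-2 (Homo sapiens), read by fluorescence polarization, with stated times of 5 min and 10 min; on this read-out lower numbers stand for stronger inhibition and higher numbers for weaker inhibition. Compound 2 `CC(C)=CCCC1=CC[C@@H](C(=O)NO)[C@H](c2ccccc2)C1` carries the change hydrogen in place of methyl on an oxygen and gives 700 nM in this assay, a step of a 3.9-fold lower number from compound 1 to compound 2 (0.59 log units; beyond the scatter). Compound 3 `CON(C)C(=O)[C@@H]1CC=C(CCC=C(C)C)C[C@H]1c1ccccc1` differs from compound 1 by methyl in place of hydrogen on an amide-type nitrogen. For compound 3 the read-out in this assay is only a limit, > 23000 nM, as shown by the limit of > 23000 nM in this assay, at which 1 of the 3 values shown sits; the step of an at least 8.5-fold higher number from compound 1 to compound 3 (0.93 log units; beyond the scatter) is therefore itself only a bound. Compound 4 `CC(C)=CCCC1=CC[C@@H](C(=O)N(C)O)[C@H](c2ccccc2)C1` stands to compound 3 as compound 2 stands to compound 1, through (hydrogen in place of methyl on an oxygen), at the same place. Among the compounds with values here, the step of a 3.9-fold lower number from compound 1 to compound 2 (0.59 log units; beyond the scatter) is the only measured guide, and it starts from a limit here, so the expectation for compound 4 in this assay is an at least 2.5-fold lower number from compound 3 to compound 4 (0.40 log units; beyond the scatter) and remains loose. Compound 4 is estimated at 9000 nM, between 2500 nM and 30000 nM.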

Compound 4, inhibition constant: 2300 nM
Estimate against measurement, compound 4: 3.9-fold (0.59 log units) above; the measured number lies below the stated range.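

In this assay, hydrogen in place of methyl on an oxygen lowers the number on both cores, and an at least 10-fold lower number from compound 3 to compound 4 (1.00 log units; beyond the scatter) is only a bound, so the direction carries over but the size does not get fixed: the same change on two cores in this assay, a 3.9-fold lower number (0.59 log units; beyond the scatter) from compound 1 to compound 2 and an at least 10-fold lower number (1.00 log units; beyond the scatter) from compound 3 to compound 4; the limit leaves it open whether they differ
Methyl in place of hydrogen on an amide-type nitrogen raises the number on both cores, with a 3.3-fold higher number from compound 2 to compound 4 (0.52 log units; beyond the scatter) as the one exact step, and hydroxy(methyl)amino in place of methoxyamino gives a 1.2-fold lower number from compound 1 to compound 4 (0.07 log units; within the scatter): the same change on two cores in this assay, an at least 8.5-fold higher number (0.93 log units; beyond the scatter) from compound 1 to compound 3 and a 3.3-fold higher number (0.52 log units; beyond the scatter) from compound 2 to compound 4; the limit leaves it open whether they differ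
Compound 3 stands only at a limit, so these pairs show a shared direction and no comparison of size: the limit of > 23000 nM in this assay, at which 1 of the 4 values shown sits.

Still open, as far as these compounds go, is what a carboxylic acid in place of the hydroxy(methyl)carbamoyl would give. Also open, from the compounds shown here alone, is whether the steps hold for ethoxy in place of methoxy.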